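A few compounds are considered here, and "the series" means these few. Any claim that something is new, unique, unknown or untested is made for them only; others in the source may bear on it.

Working notes on the series

Three compounds have been run in a functional assay on HEK293 cells for antagonist activity at transient receptor potential M8 protein (Canis lupus familiaris), read by FLIPR and calcium flux; a higher number here means a weaker inhibitor, a lower number a stronger inhibitor. Compound 1 `FC(F)(F)c1ccccc1-c1ccc2[nH]c(C3=NCC4(CCCCC4)O3)nc2c1` gives 61 nM in this assay. Compound 2 `FC(F)Oc1ccccc1-c1ccc2[nH]c(C3=NOC4(CCCCC4)C3)nc2c1` gives 2.5 nM in this assay. Compound 3 `Fc1cc(-c2ccccc2C(F)(F)F)cc2nc(C3=NOC4(CCCCC4)C3)[nH]c12` gives 2.2 nM in this assay. Compound 3 and compound 2 cannot be separated, their numbers lying within the scatter of each other; compound 1 stands well above both, beyond the scatter, so compound 3 sits at the low end of what has been measured so far.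

Compound 4 `N#Cc1cc(-c2ccccc2C(F)(F)F)cc2nc(C3=NOC4(CCCCC4)C3)[nH]c12` is the next member and has not yet been measured in this assay. It differs from compound 3 by one change: cyano in place of fluoro on an aromatic carbon. For the measured compounds named here, no pair among the measured compounds shows this change, so no step size is available for it, and the expectation rests only on the values of compound 3 and compound 2.

The expectation for compound 4 is a step of a 1.4-fold higher number from compound 3 to compound 4 (0.13 log units; within the scatter) in this assay, that is, little change beyond the scatter. The estimate for compound 4 is 3 nM, with a range from 1 nM to 10 nM.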

Compound 4, half-maximal inhibitory concentration: 0.7 nM
For compound 4 the middle estimate is 4.3-fold (0.63 log units) above the measured one, outside the stated range (below it).
By their numbers in this assay, from the lowest: compound 4; then compounds 3 and 2 (each within the scatter of the next); then compound 1.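

In this assay, cyano in place of fluoro on the aromatic carbon ortho to a fused ring and meta to a 2-(trifluoromethyl)phenyl group gives a 3.1-fold lower number from compound 3 to compound 4 (0.50 log units; beyond the scatter) on this one pair. For the compounds shown here, this is the first view of this position: a substituent change here moves the number beyond the scatter, even starting from compound 3 at 2.2 nM in this assay. Nothing in hand accounts for the gain, so it stands as an observation only.

Whether the step is specific to cyano remains open, as the compounds shown offer only two groups at this carbon and none such as an amine, a methoxy group or a carboxamide. Also open, from the compounds shown here alone, is whether the same change would carry over to the core of compound 1 or alongside the difluoromethoxy group of compound 2.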